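The source may hold more compounds than are shown below. What is called first, only, known or untested is meant among the compounds shown, and "the series" means these compounds.

Measured so far in a functional assay on the whole organism for inhibition, with Digitaria ciliaris as the target, with a stated time of 72 h, tested at 10 mg/L; on this read-out higher numbers stand for more inhibition of growth at the one concentration tested and lower numbers for less inhibition of growth:
compound 1 `COc1cc(SC)nc(NC(=S)NC(=O)c2c(-c3ccc(Cl)cc3Cl)noc2C)n1` gives 34.8%;
compound 2 `CSc1cc(C)nc(NC(=S)NC(=O)c2c(-c3ccc(Cl)cc3Cl)noc2C)n1` gives 26.7%;
compound 3 `COc1cc(OC)n2s/c(=N\C(=O)c3c(-c4ccc(Cl)cc4Cl)noc3C)nc2n1` gives 53.8%.

Compound 2 holds the lowest number of the three. For the measured compounds named here, compound 1 stands within the scatter of it, as a number 8.1 percentage points lower from compound 1 to compound 2 (within the scatter) shows; only compound 3 lies beyond the scatter of compound 2, and no single-point step connects those two.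

Compound 4 `COc1cc(OC)nc(NC(=S)NC(=O)c2c(-c3ccc(Cl)cc3Cl)noc2C)n1` differs from compound 2 by 4,6-dimethoxypyrimidin-2-yl in place of 4-methyl-6-(methylsulfanyl)pyrimidin-2-yl on an amide-type nitrogen. Going by the values given here, the one measured step that bears on it is a number 8.1 percentage points lower from compound 1 to compound 2 (within the scatter), a single methoxy-for-methyl exchange within the scatter; compound 4 carries methoxy twice. From that, no step beyond the scatter is expected in this assay, at most a small upward lean. Compound 4 is estimated at 36%, range 20% to 54%. The expected step is a number 9.3 percentage points higher from compound 2 to compound 4 (within the scatter).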

Compound 4, percent growth inhibition at one concentration: 32%
For compound 4 the middle estimate is 4 percentage points above the measured one, within the range that was stated.
By their numbers in this assay, from the lowest: compounds 2, 4 and 1 (each within the scatter of the next); then compound 3.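

In this assay, replacing 4-methyl-6-(methylsulfanyl)pyrimidin-2-yl with 4,6-dimethoxypyrimidin-2-yl on an amide-type nitrogen gives a small step (a number 5.3 percentage points higher from compound 2 to compound 4 (within the scatter)). Methoxy in place of methylsulfanyl on an aromatic carbon also stays small (a number 2.8 percentage points lower from compound 1 to compound 4 (within the scatter)), so this position now shows the methylsulfanyl group exchanged as well as the methyl group, with neither step leaving the scatter. Nothing at hand bears on the reason for these steps.

From the compounds shown here alone, whether an amine or an ethoxy group on this pyrimidine would give a step beyond the scatter remains open. So does the effect of a longer alkyl chain there.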